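Working notes: exchanging the end group on the shared chain

The source may hold more compounds than are shown below. What is called first, only, known or untested is meant among the compounds shown, and "the series" means these compounds.

In a functional assay on the whole organism with Canis familiaris (Canis lupus familiaris) as the target (on this read-out lower numbers stand for an effect already at smaller amounts and higher numbers for an effect only at larger amounts of compound), compound 1 (`OC(CSc1[nH]cnc2ncnc1-2)CN1CCN(C(c2ccccc2)c2ccccc2)CC1`) gives 0.63 mg/kg and compound 2 (`Cn1cnc2c(SCC(O)CN3CCN(C(c4ccc(F)cc4)c4ccc(F)cc4)CC3)ncnc21`) gives 1.9 mg/kg, the higher of the two numbers and beyond the scatter from compound 1. Compound 3 (`CN(CC(O)CN1CCN(C(c2ccc(F)cc2)c2ccc(F)cc2)CC1)c1[nH]cnc2ncnc1-2`) differs from compound 2 in one place: a group of 11 heavy atoms (6 carbon, 5 nitrogen; one five-membered aromatic ring with 2 hetero atoms, one six-membered aromatic ring with 2 hetero atoms) in place of a group of 11 heavy atoms (6 carbon, 4 nitrogen, 1 sulfur; one five-membered aromatic ring with 2 hetero atoms, one six-membered aromatic ring with 2 hetero atoms), on a saturated chain carbon, two bonds along the chain from an oxygen on a saturated carbon. Going by the values given here, no measured pair shows this exchange alone, and the two measured compounds differ in more than one place. No step beyond the scatter is therefore expected in this assay. The expected step is a 1.3-fold lower number from compound 2 to compound 3 (0.10 log units; within the scatter). Compound 3 is estimated at 1.5 mg/kg, with an expected range of 0.4 mg/kg to 6 mg/kg.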

Compound 3, dose for half-maximal effect: 0.74 mg/kg
Estimate against measurement, compound 3: 2.0-fold (0.31 log units) above, within the range that was stated.
By their numbers in this assay, from the lowest: compounds 1 and 3 (each within the scatter of the next); then compound 2.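

In this assay, the group of 11 heavy atoms with 5 nitrogen replacing the one with 4 nitrogen and 1 sulfur, on a saturated chain carbon, gives a 2.6-fold lower number from compound 2 to compound 3 (0.41 log units; beyond the scatter). This first one-place comparison in the series shows that the read-out responds to a change at this position, even with the heavy-atom count of the group unchanged. No measurement on hand explains the step.

The step cannot be divided among the differences within the exchanged group. From the compounds shown here alone, the effect of a simple amine or a carboxylic acid at this position remains open.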